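Dichlorophenyl Variant of a Chalcone-Like Series on Prostate Cells

The source may report more compounds than this note shows. Statements on the series, on what has been measured and on what is new or still open speak of the compounds shown alone.

Of the compounds shown here, three sharing one core have been measured in a functional assay on PC-3 cells (Homo sapiens) for antiproliferative activity, read by MTT assay, with a stated time of 72 h; on this read-out lower numbers stand for stronger inhibition and higher numbers for weaker inhibition. Compound 1 `COc1ccccc1/C=C/C(=O)c1ccc(OCC(=O)N[C@H]2CCOC2=O)cc1` gives 7240 nM. Compound 3 `O=C(COc1ccc(C(=O)/C=C/c2cccc(F)c2)cc1)N[C@H]1CCOC1=O` gives 23200 nM and stands highest of the two plain numbers, with compound 1 as its nearest neighbour through the step of a 3.2-fold higher number from compound 1 to compound 3 (0.51 log units; beyond the scatter). Compound 2 `O=C(COc1ccc(C(=O)/C=C/c2ccc(Br)cc2)cc1)N[C@H]1CCOC1=O` reached only a limit of the measurement, > 64000 nM, so no exact number exists for it; the limit of > 64000 nM in this assay, at which 1 of the 3 values shown sits, is that limit.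

Compound 4 `O=C(COc1ccc(C(=O)/C=C/c2ccc(Cl)cc2Cl)cc1)N[C@H]1CCOC1=O` differs from compound 3 in one place: 2,4-dichlorophenyl in place of 3-fluorophenyl on a double-bonded chain carbon bound to a double-bonded chain carbon.

For the measured compounds named here, two measured steps bear on this change, both swapping the group on a double-bonded chain carbon bound to a double-bonded chain carbon. The step of an at least 8.8-fold higher number from compound 1 to compound 2 (0.94 log units; beyond the scatter) brought in a 4-bromophenyl and weakened inhibition beyond the scatter, while the step of an at least 2.7-fold lower number from compound 2 to compound 3 (0.44 log units; beyond the scatter) took inhibition back toward stronger values. In its pattern of halogens, 2,4-dichlorophenyl resembles 4-bromophenyl more than 3-fluorophenyl, so a weaker result than compound 3 is expected, a step of a 1.7-fold higher number from compound 3 to compound 4 (0.24 log units; within the scatter) in this assay. Compound 4 is therefore estimated at 40000 nM, with a likely range from 15000 nM to 90000 nM, and the measurement may again end at a limit rather than a number.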

Compound 4, half-maximal inhibitory concentration: 8040 nM
For compound 4 the middle estimate is 5.0-fold (0.70 log units) above the measured one; the whole stated range lies above it.
By their numbers in this assay, from the lowest: compounds 1 and 4 (each within the scatter of the next); then compound 3. At a limit, above all of these: compound 2.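

On a double-bonded chain carbon bound to a double-bonded chain carbon, in this assay, the step of a 2.9-fold lower number from compound 3 to compound 4 (0.46 log units; beyond the scatter) shows that a halogen-bearing phenyl group can give stronger inhibition than compound 3 does, so the weakening seen with the earlier halogen compounds does not hold for every halogen pattern. The step of a 1.1-fold higher number from compound 1 to compound 4 (0.05 log units; within the scatter) places compound 4 level with compound 1, showing that a phenyl group carrying only halogens can match the 2-methoxyphenyl group here. Compound 2 stands at a limit rather than a number, so the step of an at least 7.9-fold lower number from compound 2 to compound 4 (0.90 log units; beyond the scatter) gives only a minimum size, yet it still shows that two halogen-bearing groups at this place can differ widely: the limit of > 64000 nM in this assay, at which 1 of the 4 values shown sits.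

With only three halogen patterns, these compounds cannot show whether the two chlorines of 2,4-dichlorophenyl both contribute, and a comparison with 2-chlorophenyl and 4-chlorophenyl would separate them. On these data alone, how a phenyl group carrying an amine or a carboxylic acid would behave at this place also remains open.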